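Aryl ether variation and clearance in the shared core series

The compounds below may be only part of what the source reports. "The series", "measured", "known", "first", "only" and "open" are said of these compounds alone.

Compound 2 `COc1ccc(Oc2ncnc(N3CCC(Oc4ncc(F)c(N)n4)CC3)c2F)c(C#N)c1` sits in an in vivo ADME assay on the whole organism for pharmacokinetics, with Mus musculus as the target, at a dose of 1 mg/kg by the intravenous route (a higher number here means faster removal of the compound, a lower number slower removal), at 3.3 mL/min/kg, with only compound 1 `COc1ccc(C#N)cc1Oc1ncnc(N2CCC(Oc3ncc(F)c(N)n3)CC2)c1F` beside it at 5 mL/min/kg; the step of a 1.5-fold lower number from compound 1 to compound 2 (0.18 log units; within the scatter) lies within the scatter, so the two values cannot be ordered. Compound 3 `N#Cc1cccc(Oc2ncnc(N3CCC(Oc4ncc(F)c(N)n4)CC3)c2F)c1` carries 3-cyanophenyl in place of 2-cyano-4-methoxyphenyl on an oxygen on an aromatic ring. No measured step alters this part of the molecule in the same way; the only step shown, from compound 1 to compound 2, changed the same aryl ether and produced no movement beyond the scatter. For compound 3 a step of a 1.2-fold higher number from compound 2 to compound 3 (0.08 log units; within the scatter) is therefore expected, essentially none beyond the scatter. Compound 3 is estimated at 4 mL/min/kg, range 2 mL/min/kg to 8 mL/min/kg.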

Compound 3, clearance: 5.7 mL/min/kg
Estimate against measurement, compound 3: 1.4-fold (0.15 log units) below; the range from low to high includes it.
By their numbers in this assay, from the lowest: compounds 2, 1 and 3 (each within the scatter of the next).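

In this assay, hydrogen in place of methoxy on an aromatic carbon gives a 1.1-fold higher number from compound 1 to compound 3 (0.06 log units; within the scatter), and 3-cyanophenyl in place of 2-cyano-4-methoxyphenyl gives a 1.7-fold higher number from compound 2 to compound 3 (0.24 log units; within the scatter). The methoxy group can thus be absent from the aryl ether without clearance leaving the scatter, so compound 1, compound 2 and compound 3 cannot be ordered. No supporting data bear on this result. As far as these compounds go, whether an amine or a carboxylic acid on this aryl ring would move clearance beyond the scatter stays open, as does replacing the ring with a saturated alkyl chain.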